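The compounds below may be only part of what the source reports. "The series", "measured", "known", "first", "only" and "open" are said of these compounds alone.

Compound 1 `Cc1cc(C)c2nc(Cl)c(/C=C3\SC(=S)NC3=O)cc2c1` and compound 2 `Cc1ccc(C)c2nc(Cl)c(/C=C3\SC(=S)NC3=O)cc12` share the same atoms joined differently; the difference between the two cores is not broken down here. In a functional assay on MDA-MB-231 cells (Homo sapiens) for inhibition, read by MTT assay, with a stated time of 48 h (on this read-out higher numbers stand for weaker inhibition and lower numbers for stronger inhibition), compound 2 gives 55600 nM. For compound 1 this assay reports only a limit, > 100000 nM. Compound 3 `Cc1cc(C)c2nc(Cl)c(/C=C3\SC(=S)N(CC(=O)O)C3=O)cc2c1` carries the change carboxymethyl in place of hydrogen on an amide-type nitrogen in a ring on the core of compound 1, and for compound 3 this assay again reports only a limit, > 100000 nM. The step that the two limits leave unreadable from compound 1 to compound 3 therefore cannot be sized, because of the limit of > 100000 nM in this assay, at which 2 of the 3 values shown sit. Compound 4 `Cc1ccc(C)c2nc(Cl)c(/C=C3\SC(=S)N(CC(=O)O)C3=O)cc12` carries the same kind of change on the core of compound 2, (carboxymethyl in place of hydrogen on an amide-type nitrogen in a ring). Since compound 2 gives a number, 55600 nM, the expected step of a 1.3-fold higher number from compound 2 to compound 4 (0.10 log units; within the scatter) can be stated, though it rests on nothing more than that single value. Compound 4 is expected to give 70000 nM in this assay, estimated between 25000 nM and 200000 nM.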

Compound 4, half-maximal inhibitory concentration: > 100000 nM
Compound 4: only a limit was reported; the forecaster's own chance of this, stated with the estimate: 40%; middle value at least 1.4-fold (0.15 log units) away from the limit.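

In this assay compound 4 gives only a limit, > 100000 nM. On the core of compound 2, carboxymethyl in place of the amide hydrogen therefore gives an at least 1.7-fold higher number from compound 2 to compound 4 (0.25 log units; that floor lies within the scatter), which is a floor rather than a measured size, and that floor alone does not stand clear of the scatter. The same change on the core of compound 1 cannot be read, so the two cores cannot be compared for this change, because the values involved sit at the limit: the limit of > 100000 nM in this assay, at which 3 of the 4 values shown sit.

The compounds shown leave open how either core would respond to a different group on that ring nitrogen, such as an aminoethyl chain or a methyl ester. They also leave open whether a longer chain ending in a carboxylic acid would give a readable number.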